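The compounds below may be only part of what the source reports. "The series", "measured", "known", "first", "only" and "open" are said of these compounds alone.

Values in a functional assay on EBC-1 cells (Homo sapiens) for antiproliferative activity, with a stated time of 72 h; on this read-out higher numbers stand for weaker inhibition and lower numbers for stronger inhibition:
- compound 1 `Fc1cc(-c2ccsc2)cn2c(Cc3ccc4ncccc4c3)cnc12` gives 444 nM
- compound 2 `N#Cc1cccc(-c2cc(F)c3ncc(Cc4ccc5ncccc5c4)n3c2)c1` gives 107 nM
- compound 3 `COc1ccc(-c2cc(F)c3ncc(Cc4ccc5ncccc5c4)n3c2)cc1F` gives 407 nM

Two steps fix the standing of the third entry on these numbers: a 1.1-fold lower number from compound 1 to compound 3 (0.04 log units; within the scatter) and a 3.8-fold higher number from compound 2 to compound 3 (0.58 log units; beyond the scatter) as well.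

Compound 4 `O=C(NCc1ccccn1)c1ccc(-c2cc(F)c3ncc(Cc4ccc5ncccc5c4)n3c2)cc1F` carries ((pyridin-2-yl)methyl)carbamoyl in place of methoxy on an aromatic carbon on that ring, with ((pyridin-2-yl)methyl)carbamoyl in place of methoxy, ortho to a fluoro group.

For the measured compounds named here, no measured step changes this group. Only swaps of the whole aromatic substituent are available, and the largest, a 4.1-fold lower number from compound 1 to compound 2 (0.62 log units; beyond the scatter), is modest. A modest step toward a lower number is therefore expected in this assay, with weak support for the direction. The expected change is a 3.4-fold lower number from compound 3 to compound 4 (0.53 log units; beyond the scatter) as an estimate. For compound 4 the estimate is 120 nM within a range of 30 nM to 450 nM overall.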

Compound 4, half-maximal inhibitory concentration: 5550 nM
Compound 4: the middle estimate sits 46-fold (1.67 log units) below what was measured; measured number outside the range, above it.
By their numbers in this assay, from the lowest: compound 2; then compounds 3 and 1 (each within the scatter of the next); then compound 4.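

For the compounds shown here, changing only the group ortho to a fluoro group, with the ring itself kept, gives in this assay a 14-fold higher number from compound 3 to compound 4 (1.13 log units; beyond the scatter) and so a large step, whereas the earlier steps, all swaps of the whole aromatic substituent, were modest or within the scatter. This position therefore does not accept ((pyridin-2-yl)methyl)carbamoyl in place of methoxy without a large rise in the number. Nothing available explains that rise.

With a single change here, the step cannot be divided among the amide hydrogen, the carbonyl and the pyridine ring. A primary carboxamide, a dimethylamide or an ethoxy group at this position would help separate them.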